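Iodo for (2-hydroxyethyl)amino on the shared core

The source may hold more compounds than are shown below. What is called first, only, known or untested is meant among the compounds shown, and "the series" means these compounds.

Within the data shown here, compound 2 `O=[N+]([O-])c1ccc(CSc2nc(NCCO)nc3c2ncn3[C@@H]2O[C@H](CO)[C@@H](O)[C@H]2O)cc1` stands lowest of the two values so far in an assay on K562 cells for displacement of a labelled ligand from Equilibrative nucleoside transporter 1 (Homo sapiens), read by flow cytometry, with a stated time of 45 min (on this read-out lower numbers stand for stronger inhibition and higher numbers for weaker inhibition), where compound 2 gives 86 nM; compound 1 `CCCCCNc1nc(SCc2ccc([N+](=O)[O-])cc2)c2ncn([C@@H]3O[C@H](CO)[C@@H](O)[C@H]3O)c2n1` gives 357 nM, and the only measured step is a 4.2-fold lower number from compound 1 to compound 2 (0.62 log units; beyond the scatter). Compound 3 `O=[N+]([O-])c1ccc(CSc2nc(I)nc3c2ncn3[C@@H]2O[C@H](CO)[C@@H](O)[C@H]2O)cc1` differs from compound 2 by iodo in place of (2-hydroxyethyl)amino on an aromatic carbon. Among the measured compounds shown here, no measured step exchanges the whole amino substituent for a halogen; the step from compound 1 to compound 2 varies only the chain end and bears weakly on this change. The number for compound 3 is therefore expected to rise, with wide uncertainty, by a 3.5-fold higher number from compound 2 to compound 3 (0.54 log units; beyond the scatter). Compound 3 is estimated at 300 nM, range 60 nM to 1500 nM.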

Compound 3, inhibition constant: 11 nM
Compound 3: the middle estimate sits 27-fold (1.44 log units) above what was measured; measured number below the stated range.
By their numbers in this assay, from the lowest: compound 3; then compound 2; then compound 1.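

Iodo in place of (2-hydroxyethyl)amino on this aromatic carbon gives a 7.8-fold lower number from compound 2 to compound 3 (0.89 log units; beyond the scatter), and iodo in place of pentylamino gives a 32-fold lower number from compound 1 to compound 3 (1.51 log units; beyond the scatter). An amino-linked chain at this position is therefore not required for a low number in these compounds: iodo, a single iodine atom with no hydrogen-bond donors or acceptors, gives the lowest number of the three. Nothing available accounts for this gain.

Still open, from the compounds shown here alone, is whether the gain comes from iodine itself or from the loss of the amino chain. Bromo, chloro or an unsubstituted amino group on the same carbon would bear on that question.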